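The source may hold more compounds than are shown below. What is called first, only, known or untested is meant among the compounds shown, and "the series" means these compounds.

Compound 2 `Cc1cc2occ(-c3nc(-c4ccccc4)c(-c4ccccc4)n3-c3ccc([N+](=O)[O-])cc3)c(=O)c2cc1Cl` carries a 4-nitrophenyl group on the aromatic nitrogen of the shared core. In a functional assay on HepG2 cells (Homo sapiens) for inhibition, read by MTT assay, with a stated time of 72 h (on this read-out lower numbers stand for stronger inhibition and higher numbers for weaker inhibition), compound 2 gives 25000 nM. Compound 1 `Cc1cc2occ(-c3nc(-c4ccccc4)c(-c4ccccc4)n3-c3cccc(Cl)c3)c(=O)c2cc1Cl`, which carries 3-chlorophenyl in the same place, gives 25000 nM in this assay. Within the data shown here, the single measured step, no change at the digits printed from compound 1 to compound 2 (within the scatter), shows that swapping the substituent on this aromatic nitrogen left the read-out unchanged within the scatter, so compound 2 stands level with compound 1 and there is no ordering between them.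

Compound 3 `Cc1cc2occ(-c3nc(-c4ccccc4)c(-c4ccccc4)n3-c3ccc(Br)cc3)c(=O)c2cc1Cl` has not yet been measured in this assay. Its difference from compound 2 is bromo in place of nitro on an aromatic carbon; read one bond further out, the change is 4-nitrophenyl to 4-bromophenyl. Among the measured compounds shown here, the only step that bears on it, no change at the digits printed from compound 1 to compound 2 (within the scatter), was flat, and it concerned the same aromatic nitrogen substituent, although that step changed both the group and its position while this one changes the group alone. On that basis no movement beyond the scatter is expected, so the step is estimated as no change at the digits printed from compound 2 to compound 3 (within the scatter). Compound 3 is therefore expected to give about 25000 nM in this assay, within a range from 10000 nM to 60000 nM.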

Compound 3, half-maximal inhibitory concentration: 6250 nM
Compound 3: the middle estimate sits 4.0-fold (0.60 log units) above what was measured; measured number outside the range, below it.
By their numbers in this assay, from the lowest: compound 3; then compounds 1 and 2 (each within the scatter of the next).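

In this assay the group on the phenyl ring carried by the aromatic nitrogen proved able to move the read-out: bromo in place of nitro on an aromatic carbon, para to a large group, gives a 4.0-fold lower number from compound 2 to compound 3 (0.60 log units; beyond the scatter) and this modest step lies beyond the scatter, unlike the flat step seen earlier. The swap of 4-bromophenyl in place of 3-chlorophenyl on the same nitrogen gives a 4.0-fold lower number from compound 1 to compound 3 (0.60 log units; beyond the scatter) and is also modest, so among these three compounds the substituent at this nitrogen is no longer without effect, with 4-bromophenyl alone giving the lower number. Nothing given here explains why bromo and nitro differ at this place.

On these data alone, whether the lower number is particular to bromo or would also be seen with other groups at this carbon, such as an amine, a methoxy group or a carboxylic acid, remains open. The compounds also leave open how much the position of the halogen matters, since 3-bromophenyl and 4-chlorophenyl, which would separate the halogen from its place on the ring, are not among those shown.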